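A Fluorobenzyl Variant of a Shared Diamino Core

The compounds below may be only part of what the source reports. "The series", "measured", "known", "first", "only" and "open" are said of these compounds alone.

Of the compounds shown here, three on one shared core have been measured: compound 1 `CCOC(=O)[C@H](CCC(=O)O)NC(=O)c1ccc(CNc2nc3cc(N)cc(N)c3nc2-c2ccccc2)cc1`, compound 2 `Nc1cc(N)c2nc(-c3ccccc3)c(NCc3ccc(Cl)c(Cl)c3)nc2c1` and compound 3 `CCOC(=O)[C@H](CCC(=O)O)NC(=O)c1ccc(Sc2nc3cc(N)cc(N)c3nc2-c2ccccc2)cc1`. In a functional assay on MCF7 cells (Homo sapiens) for inhibition, read by sulforhodamine B assay, with a stated time of 48 h (on this read-out higher numbers stand for lower toxicity in this test and lower numbers for higher toxicity in this test), compound 1 gives < 100000 nM, which is a limit of the assay and not a number. Compound 2 gives < 100000 nM, again only a limit. Compound 3 likewise reaches only a limit, < 100000 nM. Every result reported so far therefore sits at the limit of < 100000 nM in this assay, at which 3 of the 3 values shown sit, and compound 2 stands nowhere more precisely than that: its place among the others cannot be ranked, since none of the three carries a number.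

Compound 4 `Nc1cc(N)c2nc(-c3ccccc3)c(NCc3ccc(F)cc3)nc2c1` differs from compound 2 in a single place: 4-fluorophenyl in place of 3,4-dichlorophenyl on a saturated chain carbon bound to a nitrogen on an aromatic ring. Going by the values given here, no pair of measured compounds isolates a change of this kind, so there is no measured step to lean on, and the three limits offer no numerical direction. The account expects compound 4 to move from compound 2 by a step that the limit leaves unreadable from compound 2 to compound 4, which is a change not beyond the usual scatter. Compound 4 is accordingly estimated at 30000 nM, with a range from 3000 nM to 100000 nM, and it is expected that the assay will most likely again report only a limit rather than a number.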

Compound 4, concentration lethal to 50% of the cells: < 100000 nM
Compound 4 ended at the assay's limit; the forecaster's own chance of this, stated with the estimate: 75%; the middle value does not contradict the limit.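

No step can be read from compound 2 to compound 4, because both results are limits of the assay and not numbers: the limit of < 100000 nM in this assay, at which 4 of the 4 values shown sit.

The compounds shown leave open how compound 1, compound 2, compound 3 and compound 4 rank in this assay, and whether 4-fluorophenyl and 3,4-dichlorophenyl differ there at all.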